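The source may report more compounds than this note shows. Statements on the series, on what has been measured and on what is new or still open speak of the compounds shown alone.

Measured compounds

Compound 1 `COc1ccc(NC(=O)C(=O)c2cc(C(C)C)n3ccccc23)cn1` gives 160 nM in a functional assay on FaDu cells (Homo sapiens) for cytotoxicity, read by MTT assay, with a stated time of 72 h; on this read-out higher numbers stand for lower toxicity in this test and lower numbers for higher toxicity in this test.
Compound 2 `COCC(C)n1cc(C(=O)C(=O)Nc2ccc(OC)nc2)c2ccccc21` gives 12 nM in this assay.
Compound 3 `COCC(C)(C)n1cc(C(=O)C(=O)Nc2ccc(OC)nc2)c2ccccc21` gives 137 nM in this assay.

Compound 4 `CCc1cc(C(=O)C(=O)Nc2ccc(OC)nc2)c2ccccn12` is not yet measured. It differs from compound 1 by hydrogen in place of methyl on a saturated chain carbon bound to an aromatic carbon and a saturated chain carbon. The same kind of change has been made once already within the series, from compound 3 to compound 2, where it reads hydrogen in place of methyl on a saturated chain carbon bound to an aromatic nitrogen and two saturated chain carbons and gave an 11-fold lower number from compound 3 to compound 2 (1.06 log units; beyond the scatter). The two places are not the same: in the measured pair the carbon that loses the methyl is bound to an aromatic nitrogen and two saturated chain carbons, whereas in compound 1 it is bound to an aromatic carbon and a saturated chain carbon. The difference between the core of compound 1 and the core of compound 3 is not broken down here, and compound 1 and compound 3 stand within the scatter of each other in this assay.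

Since the change in compound 4 sits on a different core and at a differently surrounded place, the measured step is taken as a pointer rather than a rule. Within the data shown here, a smaller step in the same direction, a 2.7-fold lower number from compound 1 to compound 4 (0.43 log units; beyond the scatter), is expected, because the only precedent, an 11-fold lower number from compound 3 to compound 2 (1.06 log units; beyond the scatter), is large but rests on one pair only. Compound 4 is therefore estimated at 60 nM, with a likely range from 20 nM to 200 nM.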

Compound 4, concentration lethal to 50% of the cells: 110 nM
Compound 4: middle estimate off by 1.8-fold (0.26 log units), on the low side, within the range that was stated.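

In this assay, going from isopropyl to ethyl on the core of compound 1 gives a 1.5-fold lower number from compound 1 to compound 4 (0.16 log units; within the scatter), so this step does not separate the two compounds. The two pairs differ both in the core and in what surrounds the carbon that loses the methyl, and with a single pair on each core the data cannot tell these two differences apart, so no rule for this change across the series follows from them. What they do show is that the size of the step seen on one core did not carry over to the other:  the same change on two cores in this assay, an 11-fold lower number (1.06 log units; beyond the scatter) from compound 3 to compound 2 and a 1.5-fold lower number (0.16 log units; within the scatter) from compound 1 to compound 4, 7.8-fold (0.89 log units) apart, beyond the scatter of two such steps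

Still open, as far as these compounds go, is how a longer chain, or a chain ending in an amine or a carboxylic acid, would read in this assay at either place where the methyl was replaced by hydrogen. Also open, from the compounds shown here alone, is whether a further core carrying the same change would give a step closer to the large one or to the one within the scatter, and whether that would follow the core or the surroundings of the carbon that loses the methyl.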